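This account rests on a few compounds, and the source may have more. Where it says the series, first, only, none or still open, it means among the compounds named here.

The measured compounds in a functional assay on HeLa cells (Homo sapiens) for cytotoxicity, read by sulforhodamine B assay, with a stated time of 48 h; a lower number here means a stronger inhibitor, a higher number a weaker inhibitor:

compound 1, `CC(=O)OC[C@H]1O[C@@H](n2cc(CN3C(=O)/C(=C/c4ccccc4)c4ccccc43)nn2)[C@H](OC(C)=O)[C@@H](OC(C)=O)[C@@H]1OC(C)=O`, 37100 nM
compound 2, `CC(=O)OC[C@H]1O[C@@H](n2cc(CN3C(=O)/C(=C/c4ccc(C)cc4)c4ccccc43)nn2)[C@H](OC(C)=O)[C@@H](OC(C)=O)[C@@H]1OC(C)=O`, 85600 nM
compound 3, `CC(=O)OC[C@H]1O[C@@H](n2cc(CN3C(=O)/C(=C\C=C\c4ccccc4)c4ccccc43)nn2)[C@H](OC(C)=O)[C@@H](OC(C)=O)[C@@H]1OC(C)=O`, 98100 nM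

Compound 3 and compound 2 give numbers that lie within the scatter of each other, so nothing separates them. Against compound 1, compound 3 sits higher, and that gap is beyond the scatter. Within the data shown here, the only step measured so far, a 2.3-fold higher number from compound 1 to compound 2 (0.36 log units; beyond the scatter), concerns a methyl in place of hydrogen on an aromatic carbon and gave a modest rise.

Compound 4, `CC(=O)OC[C@H]1O[C@@H](n2cc(CN3C(=O)/C(=C/C=C/c4ccccc4)c4ccccc43)nn2)[C@H](OC(C)=O)[C@@H](OC(C)=O)[C@@H]1OC(C)=O`, is the geometric partner of compound 3: the two compounds have the same atoms and bonds and differ only in configuration as drawn: 1 of 7 stereo elements differ; a double bond is drawn Z in compound 3 and E in compound 4. Among the measured compounds shown here, no measured pair shows what a change of double-bond configuration alone does here, and the step from compound 1 to compound 2 adds an atom rather than redrawing a bond, so it bears on compound 4 only by showing that small changes to this series move the number modestly. For the measured compounds named here, with no direct precedent, the step of a 1.2-fold lower number from compound 3 to compound 4 (0.09 log units; within the scatter) is expected to stay within the scatter. Compound 4 is therefore estimated at about 80000 nM in this assay, with a range from 30000 nM to 200000 nM.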

Compound 4, half-maximal inhibitory concentration: > 100000 nM
Compound 4: only a limit was reported; the forecaster's own chance of this, stated with the estimate: 15%; middle value at least 1.2-fold (0.09 log units) from the limit.
By their numbers in this assay, from the lowest: compound 1; then compounds 2 and 3 (each within the scatter of the next). At a limit, above all of these: compound 4.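

In this assay compound 4 gives > 100000 nM, which is a limit of the assay and not a number. The floors of an at least 1.0-fold higher number from compound 3 to compound 4 (0.00 log units; that floor lies within the scatter) and an at least 1.1-fold higher number from compound 2 to compound 4 (0.06 log units; that floor lies within the scatter) both lie within the scatter, so changing the double bond from Z to E shows no measurable change here, though the limit cannot exclude one. Only an at least 2.6-fold higher number from compound 1 to compound 4 (0.43 log units; beyond the scatter) lies beyond the scatter, showing that 2-phenylethenyl in place of phenyl on a double-bonded chain carbon bound to a double-bonded ring carbon raises the number in this assay.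

As far as these compounds go, how far compound 4 lies past its limit stays open, and with it the true size of the configuration step. Also open, from the compounds shown here alone, is whether hydroxyl groups in place of the acetyl groups, or an amine or a carboxylic acid on the phenyl, would bring the number below that of compound 1.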